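Replacing the carbonyl with a methylene on the ring nitrogen

The source may report more compounds than this note shows. Statements on the series, on what has been measured and on what is new or still open speak of the compounds shown alone.

Of the compounds shown here, three with a shared core have been measured in a functional assay on isolated protein for agonist activity at Glucose-dependent insulinotropic receptor (Homo sapiens), read by HTRF and cAMP accumulation; on this read-out higher numbers stand for larger maximal responses and lower numbers for smaller maximal responses. Compound 1 `CC(C)OC(=O)N1CCC(O[C@H]2CC[C@H](Oc3cnc(S(C)(=O)=O)cn3)CC2)CC1` gives 110%. Compound 2 `C[C@H](CF)OC(=O)N1CCC(O[C@H]2CC[C@H](Oc3cnc(S(C)(=O)=O)cn3)CC2)CC1` gives 108%. Compound 3 `CS(=O)(=O)c1cnc(O[C@H]2CC[C@H](OC3CCN(C(=O)C4(C(F)(F)F)CC4)CC3)CC2)cn1` gives 107%. The step of a number 2 percentage points lower from compound 1 to compound 2 (within the scatter) and the step of a number 3 percentage points lower from compound 1 to compound 3 (within the scatter) both stay within the scatter, as does the step of a number 1 percentage points lower from compound 2 to compound 3 (within the scatter). Compound 3 therefore stands lowest of the three numbers, but each of its neighbours lies within the scatter of it, so no order among the three can be claimed.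

Compound 4 `CS(=O)(=O)c1cnc(O[C@H]2CC[C@H](OC3CCN(CC4(C(F)(F)F)CC4)CC3)CC2)cn1` differs from compound 3 in one place: (1-(trifluoromethyl)cyclopropyl)methyl in place of (1-(trifluoromethyl)cyclopropyl)carbonyl on an amine nitrogen in a ring. The measured steps all concern the group on the carbonyl carbon; none of them removes the carbonyl itself or touches the amine nitrogen in a ring, so none bears directly on this change. What they do show is that, across three different groups at this end of the molecule, the largest response stayed within the scatter. On that basis the expected step of a number 4 percentage points lower from compound 3 to compound 4 (within the scatter) is none beyond the scatter, with somewhat wider uncertainty than the measured steps because the change is of a new kind. Compound 4 is expected to give about 103% in this assay, within a range from 88% to 116%.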

Compound 4, largest response reached (Emax), in percent of the reference or control that the assay uses: 116%
Estimate against measurement, compound 4: 13 percentage points below; the range from low to high includes it.
By their numbers in this assay, from the lowest: compounds 3, 2, 1 and 4 (each within the scatter of the next).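

Swapping the carbonyl for a methylene on the amine nitrogen in a ring is a change of a new kind, since it removes the only hydrogen-bond acceptor in this group, yet in this assay the result is a number 9 percentage points higher from compound 3 to compound 4 (within the scatter). Set against the two compounds that carry an oxygen-containing carbonyl group at the same nitrogen, the results are a number 8 percentage points higher from compound 2 to compound 4 (within the scatter) and a number 6 percentage points higher from compound 1 to compound 4 (within the scatter), so among these four compounds a carbonyl on this nitrogen is not required for a full maximal response, and the ring nitrogen can carry either a carbonyl group or a methylene-linked group with no step beyond the scatter. Nothing available here explains why the response holds across this change.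

What the compounds shown leave open is whether this tolerance extends to other groups on the same nitrogen, such as a plain isopropyl, a longer alkyl chain or a sulfonyl group. They also leave open how much of each compound is needed to reach this response, as the largest response alone does not tell that.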